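This account rests on a few compounds, and the source may have more. Where it says the series, first, only, none or still open, it means among the compounds named here.

Measured in a functional assay on MCF7 cells (Homo sapiens) for antiproliferative activity, read by MTT assay, with a stated time of 48 h; on this read-out higher numbers stand for weaker inhibition and lower numbers for stronger inhibition:
- compound 1 `C#Cc1cccc(Nc2ncnc3cc(NC(=O)/C=C/c4ccccc4)sc23)c1`: 75600 nM
- compound 2 `COc1ccc(/C=C/C(=O)Nc2cc3c(Nc4ccc(Cl)c(Cl)c4)ncnc3s2)cc1`: 20100 nM
- compound 3 `N#Cc1cccc(Nc2ncnc3cc(NC(=O)/C=C/c4ccccc4)sc23)c1`: > 100000 nM, a limit of the assay and not a number

Of the two values that are actual numbers, compound 2 has the lower, and compound 1 lies above it by more than the scatter. The next compound to be tested is compound 4 `O=C(/C=C/c1ccccc1)Nc1cc2c(Nc3ccc(Cl)c(Cl)c3)ncnc2s1`, which has hydrogen in place of the methoxy group of compound 2 on an aromatic carbon, para to a large group: hydrogen in place of methoxy on an aromatic carbon. This turns 4-methoxyphenyl into phenyl.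

Among the measured compounds shown here, the only measured step, an at least 1.3-fold higher number from compound 1 to compound 3 (0.12 log units; that floor lies within the scatter), is a different change, so it does not size this one. Compound 1, at 75600 nM, also carries the 2-phenylethenyl group, but it differs from compound 4 elsewhere too, so it offers only a weak hint towards a higher number. A small rise is therefore expected in this assay, possibly no larger than the scatter. The estimate corresponds to a 1.6-fold higher number from compound 2 to compound 4 (0.20 log units; within the scatter), which is an expected step and not a measured one. For compound 4 the estimated value is 32000 nM, with an expected range of 11000 nM to 90000 nM.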

Compound 4, half-maximal inhibitory concentration: 15300 nM
Estimate against measurement, compound 4: 2.1-fold (0.32 log units) above, within the range that was stated.
By their numbers in this assay, from the lowest: compounds 4 and 2 (each within the scatter of the next); then compound 1. At a limit, above all of these: compound 3.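

Hydrogen in place of methoxy, on an aromatic carbon para to a large group, gives (a 1.3-fold lower number from compound 2 to compound 4 (0.12 log units; within the scatter)) in this assay. Among the compounds shown here, this is the first measured step at this position, and the earlier compounds, whose only step was a different change, could not size it: here 4-methoxyphenyl and phenyl give values within the scatter of each other, so this pair shows no need for the methoxy group to keep the value. Nothing in the evidence available bears on this result.

The compounds shown leave open how a carboxylic acid, an amine or a chlorine at this same carbon would read. They also leave open whether hydrogen in place of methoxy would give a similar step with a different group on the shared core.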